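The source may hold more compounds than are shown below. What is called first, only, known or untested is meant among the compounds shown, and "the series" means these compounds.

Values in a functional assay (trachea) with Cavia porcellus as the target; a lower number here means a stronger inhibitor, a higher number a weaker inhibitor
- compound 1 `CC(C)n1nc(-c2cccnc2)c2ccccc2c1=O` at 3090 nM
- compound 2 `CCn1nc(-c2cncs2)c2ccccc2c1=O` at 562 nM
- compound 3 `CC(C)n1nc(-c2cncs2)c2ccccc2c1=O` at 3390 nM

Compound 3 holds the high end of these numbers, level with compound 1 and well apart from compound 2. Compound 4 `CC(C)Cn1nc(-c2cncs2)c2ccccc2c1=O` differs from compound 3 in one group, isobutyl in place of isopropyl on an aromatic nitrogen. The swap of pyridin-3-yl for 1,3-thiazol-5-yl (a 1.1-fold higher number from compound 1 to compound 3 (0.04 log units; within the scatter)) concerns another group and says little here. Among the measured compounds shown here, only the modest chain step (a 6.0-fold higher number from compound 2 to compound 3 (0.78 log units; beyond the scatter)) bears on this change, and no measured compound carries isobutyl. In this assay, on these data alone, no step beyond the scatter is therefore expected, and the direction stays open. The expected step is small (a 1.4-fold lower number from compound 3 to compound 4 (0.13 log units; within the scatter)). Compound 4 is estimated at 2500 nM with an expected range from 700 nM to 9000 nM on present data.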

Compound 4, half-maximal inhibitory concentration: 2400 nM
Compound 4: the middle estimate sits 1.0-fold (0.02 log units) above what was measured; the measured number falls inside the stated range.
By their numbers in this assay, from the lowest: compound 2; then compounds 4, 1 and 3 (each within the scatter of the next).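

On the aromatic nitrogen, isobutyl in place of isopropyl gives no change beyond the scatter in this assay (a 1.4-fold lower number from compound 3 to compound 4 (0.15 log units; within the scatter)). The gap to the ethyl compound persists with isobutyl (a 4.3-fold higher number from compound 2 to compound 4 (0.63 log units; beyond the scatter)), so with 1,3-thiazol-5-yl in the series, both larger chains stand apart from ethyl. No supporting data bear on the reason for this gap.

Still open, on these data alone, is whether a straight butyl chain, a cyclopropylmethyl group or a chain carrying an amine would stay level with isobutyl. Also open, as far as these compounds go, is how isobutyl behaves with pyridin-3-yl in place of 1,3-thiazol-5-yl.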